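The source may hold more compounds than are shown below. What is called first, only, known or untested is meant among the compounds shown, and "the series" means these compounds.

Measured so far:
- compound 1, `CCCCCc1nc2[nH]c(-c3ccc(Cl)cc3)cc(=O)n2n1`: 8250 nM
- compound 2, `O=c1cc(Cc2ccc(Cl)cc2)[nH]c2nc(Cc3ccc(F)cc3)nn12`: 3650 nM
- compound 3, `Cc1ccc(Cc2nc3[nH]c(Cc4ccccc4)cc(=O)n3n2)cc1`: 2470 nM

Among these three numbers compound 2 holds the second highest. Its nearest neighbour is compound 3, whose value sits within the usual scatter of compound 2, so no order between the two can be read. Its furthest is compound 1, whose value lies beyond the scatter on the weaker side.

Compound 4, `O=c1cc(-c2ccccc2)[nH]c2nc(Cc3ccc(F)cc3)nn12`, has not been measured. It differs from compound 2 in one place: phenyl in place of 4-chlorobenzyl on an aromatic carbon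

Among the compounds with values here, no directly measured step of this kind exists in the set, so the size of the change in a functional assay on Cortical neurone cells (Mus musculus, strain C57BL/6), read by FLIPR and calcium flux, with a stated time of 8 min (a higher number here means a weaker inhibitor, a lower number a stronger inhibitor), is uncertain. Within the data shown here, a modest weakening is expected rather than a gain, because compound 1 gives 8250 nM and is the only compound here carrying a ring joined without a single-carbon link, although that rests on one compound only. For compound 4 the expected step from its parent is a 1.9-fold higher number from compound 2 to compound 4 (0.28 log units; within the scatter), and compound 4 is estimated at 7000 nM in this assay, with a likely range from 2500 nM to 20000 nM.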

Compound 4, half-maximal inhibitory concentration: 2520 nM
Estimate against measurement, compound 4: 2.8-fold (0.44 log units) above; the measured number falls inside the stated range.
By their numbers in this assay, from the lowest: compounds 3, 4 and 2 (each within the scatter of the next); then compound 1.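

In this assay, phenyl in place of 4-chlorobenzyl on this aromatic carbon gives a 1.4-fold lower number from compound 2 to compound 4 (0.16 log units; within the scatter), so a ring joined directly here brings no change beyond the scatter. The swap removes the single-carbon link and the chlorine together, and this one step cannot separate the two. No measured data explain the step.

Still open, going by these compounds, is whether the chlorine and the link have separate effects that cancel here. An amine, a carboxylic acid or a longer chain on this carbon also remains untested in the compounds shown.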